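Series notes: antiproliferative screen, step to compound 3

A few compounds are considered here, and "the series" means these few. Any claim that something is new, unique, unknown or untested is made for them only; others in the source may bear on it.

Measured so far:
compound 1 `COc1cc(C(=O)N/N=C/c2cccc(F)c2)cc(OC)c1OC`: 53.5%
compound 2 `COc1cc(C2=NN(C(C)=O)C(c3cccc(OC)c3OC)O2)cc(OC)c1OC`: 35%

Both numbers come from a functional assay on PC-3 cells (Homo sapiens) for antiproliferative activity, read by MTT assay, tested at 1 uM; a lower number here means a weaker effect, a higher number a stronger effect of the compound at the concentration tested. Compound 2 stands lowest of the two; its nearest neighbour is compound 1, whose reading is higher by a margin beyond the usual scatter. Going by the values given here, no pair differing in one place has been measured, so no step size is known.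

Compound 3 `COc1cc(C2=NN(C(C)=O)C(c3ccccc3C(F)(F)F)O2)cc(OC)c1OC` is to be measured in this assay. It differs from compound 2 by 2-(trifluoromethyl)phenyl in place of 2,3-dimethoxyphenyl on a saturated ring carbon. Nothing measured in the series shows what such an exchange does, so the size and direction of the step are open; the working expectation is a step of no change at the digits printed from compound 2 to compound 3 (within the scatter) from compound 2, not beyond the scatter. On that basis compound 3 is expected to give about 35%, with a range from 15% to 55%.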

Compound 3, a percentage reported as inhibition, at one concentration (the size of the read-out at that concentration, not a potency): -11%
The estimate for compound 3 lay 46 percentage points above the measured number, outside the stated range (below it).
By their numbers in this assay, from the lowest: compound 3; then compound 2; then compound 1.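

In this assay the aryl group on the saturated ring carbon is a sensitive place in the series: 2-(trifluoromethyl)phenyl in place of 2,3-dimethoxyphenyl gives a large step of a number 46 percentage points lower from compound 2 to compound 3 (beyond the scatter) that lies beyond the scatter. The reading of compound 3 at -11% shows no inhibition at the concentration tested, so this single exchange removes the effect seen with compound 2 rather than merely trimming it. No measured property of these compounds bears on this step.

The exchange takes away both methoxy groups and brings in the trifluoromethyl group in one move, so the shares of loss and gain in the step stay unresolved. Also open, on these data alone, is how this position responds to a phenyl ring carrying an amine or a carboxylic acid.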